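From Isopropyl to Cyclopentyl on the Sulfur

A few compounds are considered here, and "the series" means these few. Any claim that something is new, unique, unknown or untested is made for them only; others in the source may bear on it.

Compound 1 `Cc1c(Cc2c(F)cccc2Cl)nc(SC(C)C)[nH]c1=O`: > 76000 nM (a limit)
Compound 2 `CCC(c1nc(SC(C)C)[nH]c(=O)c1C)c1c(F)cccc1Cl`: > 3000 nM (a limit)

In an ADME assay on MT4 cells (Homo sapiens) for activation, read by MTT assay (on this read-out higher numbers stand for lower toxicity in this test and lower numbers for higher toxicity in this test), compound 2 gives > 3000 nM, which is a limit of the assay and not a number. Among the compounds with values here, compound 1, the only other compound measured, also stands at a limit, with > 76000 nM. Compound 2 therefore cannot be placed in any order against it.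

The next compound, compound 3 `CCC(c1nc(SC2CCCC2)[nH]c(=O)c1C)c1c(F)cccc1Cl`, differs from compound 2 in one group: cyclopentyl in place of isopropyl on a sulfur. Within the data shown here, the only measured step, a step that the two limits leave unreadable from compound 1 to compound 2, lies elsewhere in the molecule and offers no size. Among the measured compounds shown here, no measured step touches the group on the sulfur, so no size can be carried over to this assay.

The expectation leans on compound 2, with its limit of > 3000 nM. Compound 3 is expected to stay on the low-toxicity side of that limit, and the assay may again report only a limit. The estimated step is a step that the limit leaves unreadable from compound 2 to compound 3, a rough figure in an upward direction. For compound 3 the estimate is 15000 nM, expected to fall between 3000 nM and 76000 nM.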

Compound 3, half-maximal cytotoxic concentration: > 3000 nM
Compound 3 was reported as a limit (the forecaster's own chance of this, stated with the estimate: 55%); the middle value does not contradict the limit.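

In this assay compound 3 gives > 3000 nM, which is a limit of the assay and not a number. Compound 2 also stands at a limit, and no step can be read between compound 2 and compound 3. As far as these compounds go, whether cyclopentyl in place of isopropyl on a sulfur changes toxicity in this test at all remains open.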